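This account rests on a few compounds, and the source may have more. Where it says the series, first, only, none or still open, it means among the compounds named here.

In a functional assay on EMT6 cells (Mus musculus) for cytotoxicity, with a stated time of 4 h (on this read-out higher numbers stand for weaker inhibition and lower numbers for stronger inhibition), the shared core of compound 1 `CS(=O)(=O)N1CC(CCl)c2ccc(O)cc21` gives 7700 nM. Compound 2 `CNc1ccc2c(c1)N(S(C)(=O)=O)CC2CCl` carries a methylamino group where compound 1 has a hydroxy group; in this assay compound 2 gives 13000 nM, so that a 1.7-fold higher number from compound 1 to compound 2 (0.23 log units; within the scatter). Compound 3 `CS(=O)(=O)N1CC(CCl)c2ccc(S)cc21` carries a sulfanyl group in the same position; its result in this assay is a limit of the assay rather than a number, > 200000 nM. Measured against the two proper numbers, compound 2 stands highest, but compound 1 lies within the scatter of it; the third value is only a limit.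

Compound 4 `CSc1ccc2c(c1)N(S(C)(=O)=O)CC2CCl` is the compound still to be measured. It differs from compound 2 in one place: methylsulfanyl in place of methylamino on an aromatic carbon.

Within the data shown here, the nearest measured step is the one from compound 2 to compound 3, in which the methylamino group gave way to a sulfanyl group: an at least 15-fold higher number from compound 2 to compound 3 (1.18 log units; beyond the scatter). The step from compound 1 to compound 3, hydroxy to sulfanyl, went the same way: an at least 25-fold higher number from compound 1 to compound 3 (1.41 log units; beyond the scatter). Both replacements by a sulfur-linked group emptied this assay of measurable inhibition, and the methylsulfanyl group of compound 4 differs from the sulfanyl group of compound 3 only by the added methyl. A large rise in the number, beyond the scatter, is therefore expected for compound 4, with a real chance that only a limit is reported. The expected step is a 12-fold higher number from compound 2 to compound 4 (1.06 log units; beyond the scatter), so that compound 4 is estimated at 150000 nM, within a range from 30000 nM to 600000 nM.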

Compound 4, half-maximal inhibitory concentration: > 200000 nM
Compound 4 gave a limit, no number; the forecaster's own chance of this, stated with the estimate: 50%; middle value at least 1.3-fold (0.12 log units) from the limit.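

Adding a methyl to the sulfur does not bring back a measurable number in this assay: methylsulfanyl in place of methylamino gives an at least 15-fold higher number from compound 2 to compound 4 (1.18 log units; beyond the scatter), and methylsulfanyl in place of hydroxy gives an at least 25-fold higher number from compound 1 to compound 4 (1.41 log units; beyond the scatter). At this place on the aromatic ring, then, both sulfur-linked groups shown, with or without the methyl, go with a large rise compared with the nitrogen-linked and oxygen-linked groups, so the rise seen with compound 3 does not depend on the hydrogen on its sulfur. Compound 3 and compound 4 both stop at a limit of the assay rather than at a number, so the step between them cannot be read: the limit of > 200000 nM in this assay, at which 2 of the 4 values shown sit.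

From the compounds shown here alone, how far beyond that limit either sulfur compound lies stays open, and with it what the methyl on sulfur changes. Also open, going by these compounds, is whether the rise belongs to the sulfur link itself, which a methoxy group, a plain amine or a longer chain on the sulfur, such as ethylsulfanyl, at the same place would help to show.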